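Reversing the aromatic ring swap on the chain terminus

The source may report more compounds than this note shows. Statements on the series, on what has been measured and on what is new or still open speak of the compounds shown alone.

Compound 2 `Cc1cc(OCCCCCCC[n+]2ccccc2)cc(-n2cc(C(=O)Nc3cc(F)cc(F)c3)c(=O)c3ccc(N(C)C)nc32)c1` carries the shared core with a long chain ending in a charged aromatic ring; in an assay on LX2 cells for inhibition of COL1A1 promoter (Homo sapiens), read by a luciferase reporter, with a stated time of 24 h, tested at 50 uM (a lower number here means a weaker effect, a higher number a stronger effect of the compound at the concentration tested), compound 2 gives 61%. Compound 1 `Cc1cc(OCCCCCCC[N+]2(C)CCCCC2)cc(-n2cc(C(=O)Nc3cc(F)cc(F)c3)c(=O)c3ccc(N(C)C)nc32)c1` differs only in the group at that chain end, and in this assay compound 1 gives 79.7%. Of the two numbers, that of compound 2 is the lower one; the step of a number 18.7 percentage points lower from compound 1 to compound 2 (beyond the scatter) marks how far it falls short.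

Compound 3 `CC[N+]1(CCCCCCCOc2cc(C)cc(-n3cc(C(=O)Nc4cc(F)cc(F)c4)c(=O)c4ccc(N(C)C)nc43)c2)CCCCC1` is not yet measured. Against compound 2 the change is a group of 8 heavy atoms (7 carbon, 1 nitrogen; one six-membered non-aromatic ring with 1 hetero atom) in place of a group of 6 heavy atoms (5 carbon, 1 nitrogen; one six-membered aromatic ring with 1 hetero atom), on a saturated chain carbon, seven bonds along the chain from an oxygen on an aromatic ring. For the measured compounds named here, it undoes the ring swap that separated compound 1 from compound 2 and brings back a six-membered non-aromatic ring with 1 hetero atom, so the only step that bears on it is a number 18.7 percentage points lower from compound 1 to compound 2 (beyond the scatter), read in reverse. A rise of about that size is therefore expected, a number 17 percentage points higher from compound 2 to compound 3 (beyond the scatter), landing close to the number of compound 1. For compound 3 in this assay the estimate is 78%, with a range from 64% to 90%.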

Compound 3, a percentage reported as inhibition, at one concentration (the size of the read-out at that concentration, not a potency): 86.6%
The estimate for compound 3 lay 8.6 percentage points below the measured number; the measured number falls inside the stated range.
By their numbers in this assay, from the lowest: compound 2; then compounds 1 and 3 (each within the scatter of the next).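

In this assay, the swap from the charged aromatic ring to a saturated ring at the chain end gives a number 25.6 percentage points higher from compound 2 to compound 3 (beyond the scatter), so the gap first seen between compound 1 and compound 2 also appears with a second saturated ring, one that carries ethyl rather than methyl on its nitrogen. Adding that one carbon to the group on the ring nitrogen gives a number 6.9 percentage points higher from compound 1 to compound 3 (within the scatter), so this read-out does not separate the two saturated rings, and among the compounds shown only compound 2, the sole aromatic example, stands apart. No measurement is available that explains the difference between the aromatic and saturated rings at this chain end.

The compounds shown leave open whether a propyl or benzyl group on the ring nitrogen, a five-membered pyrrolidine ring, or an uncharged tertiary amine at the chain end would keep the read-out at the level of compound 1 and compound 3. They also leave open how a shorter or longer chain would behave with the saturated rings, and whether these compounds would show a stronger or weaker effect at other concentrations, as each read-out gives the size of the effect at one concentration only.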